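Removing the ethylpiperazine from compound 3

The source may report more compounds than this note shows. Statements on the series, on what has been measured and on what is new or still open speak of the compounds shown alone.

Measured in an ADME assay on microsomes from liver (Rattus norvegicus) for metabolic stability, read by LC-MS, with a stated time of 10 min, tested at 0.5 uM; a lower number here means that less of the compound is left, a higher number that more of the compound is left
compound 1 `c1ccc2c(c1)CN[C@@H](CN(CC1CCNCC1)[C@H]1CCCc3cccnc31)C2` gives 65%
compound 2 `CN1CCN(CCCN(C[C@H]2Cc3ccccc3CN2C)[C@H]2CCCc3cccnc32)CC1` gives 2%
compound 3 `CCN1CCN(CCCN(C[C@H]2Cc3ccccc3CN2)[C@H]2CCCc3cccnc32)CC1` gives 1%

Compound 3 lies within the scatter of compound 2 and far under compound 1 on this assay. Compound 4 `c1ccc2c(c1)CN[C@@H](CN(CC[C@H]1CCCNC1)[C@H]1CCCc3cccnc31)C2` differs from compound 3 by piperidin-3-yl in place of (4-ethylpiperazin-1-yl)methyl on a saturated chain carbon, two bonds along the chain from an amine nitrogen, with piperidin-3-yl in place of (4-ethylpiperazin-1-yl)methyl on a saturated chain carbon, two bonds along the chain from an amine nitrogen. Going by the values given here, the one measured step that bears on this is a number 64 percentage points lower from compound 1 to compound 3 (beyond the scatter), a large one with 2-(4-ethylpiperazin-1-yl)ethyl in place of piperidin-4-yl. Among the compounds with values here, no measured compound carries piperidin-3-yl, so a large rise, not a full reversal, is expected: a number 49 percentage points higher from compound 3 to compound 4 (beyond the scatter). For compound 4 the estimate is 50%, with an expected range from 25% to 75%.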

Compound 4, percent of the compound remaining: 55%
Beside the measured number, compound 4's estimate is 5 percentage points below it; the measured number falls inside the stated range.
By their numbers in this assay, from the lowest: compounds 3 and 2 (each within the scatter of the next); then compounds 4 and 1 (each within the scatter of the next).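

In this assay the change from the ethylpiperazine side chain to piperidin-3-yl gives a number 54 percentage points higher from compound 3 to compound 4 (beyond the scatter) and shows that this chain position can carry a far higher number than compound 3 suggested. The comparison with the piperidin-4-yl compound gives a number 10 percentage points lower from compound 1 to compound 4 (within the scatter) and so does not separate (piperidin-3-yl)methyl from piperidin-4-yl at this place. No measurement given here accounts for either step.

As far as these compounds go, what a morpholine or an unsubstituted piperazine would give at this place remains open. Also open, from the compounds shown here alone, is whether the low numbers follow the piperazine ring or its ethyl group.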